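The source may report more compounds than this note shows. Statements on the series, on what has been measured and on what is new or still open speak of the compounds shown alone.

Working notes on the series. Compound 1 `CC1CCN(c2ccc3cc(NC(=O)CCc4ccc(C(F)(F)F)cc4)ccc3n2)C1` gives 400 nM in a functional assay on HEK293 cells for activation of melanin-concentrating hormone receptor 1 (Rattus norvegicus), read by inositol phosphate accumulation; on this read-out higher numbers stand for an effect only at larger amounts of compound and lower numbers for an effect already at smaller amounts. Compound 2 `CN(C)c1ccc2cc(NC(=O)CCc3ccc(C(F)(F)F)cc3)ccc2n1` gives 110 nM in this assay. Among the compounds with values here, the single measured step, a 3.6-fold lower number from compound 1 to compound 2 (0.56 log units; beyond the scatter), is the only comparison so far, and on it compound 2 holds the lowest of the two numbers, with compound 1 as its nearest neighbour beyond the scatter.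

Compound 3 `CC(=O)NC1CCN(c2ccc3cc(NC(=O)CCc4ccc(C(F)(F)F)cc4)ccc3n2)C1` is not yet measured. Its difference from compound 2 is 3-acetamidopyrrolidin-1-yl in place of dimethylamino on an aromatic carbon. Within the data shown here, the one measured step bears on this change: it shows that a pyrrolidin-1-yl group bearing a methyl, in place of dimethylamino, carried a modest rise in the number, as seen in a 3.6-fold lower number from compound 1 to compound 2 (0.56 log units; beyond the scatter). The change to compound 3 reinstates a pyrrolidin-1-yl ring, now with an acetamido substituent, so a rise of similar size is expected. For compound 3 the estimate in this assay is 350 nM, within 120 nM to 1000 nM. This expectation corresponds to a step of a 3.2-fold higher number from compound 2 to compound 3 (0.50 log units; beyond the scatter).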

Compound 3, half-maximal effective concentration: 440 nM
For compound 3 the middle estimate is 1.3-fold (0.10 log units) below the measured one; the range from low to high includes it.
By their numbers in this assay, from the lowest: compound 2; then compounds 1 and 3 (each within the scatter of the next).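

In this assay the 3-acetamidopyrrolidin-1-yl group next to the ring nitrogen carries a 4.0-fold higher number from compound 2 to compound 3 (0.60 log units; beyond the scatter) and so joins the 3-methylpyrrolidin-1-yl group of compound 1 on the higher side of compound 2. Acetamido in place of methyl on the saturated ring carbon gives a 1.1-fold higher number from compound 1 to compound 3 (0.04 log units; within the scatter) and so does not separate the two ring substituents on this read-out, despite the added hydrogen-bond donor and acceptor counted for the acetamido group. No measurement in hand gives a reason for the higher numbers of the two ring compounds.

The compounds shown leave open how the unsubstituted pyrrolidin-1-yl group would read against dimethylamino at this position. They also leave open whether a free amine or a carboxylic acid on the same ring carbon would stay level with methyl and acetamido.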